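The source may report more compounds than this note shows. Statements on the series, on what has been measured and on what is new or still open speak of the compounds shown alone.

Measured so far:
- Compound 1 `Cc1oc(-c2c(C)c(C)c(C)c(C)c2C)nc1CN1CCC(C(=O)NCCCN2C[C@H](C)C[C@H](C)C2)CC1` gives 455 10^-6 cm/s
- Compound 2 `Cc1ccccc1-c1nc(CN2CCC(C(=O)NCCCN3CC(C)(C)CC(C)(C)C3)CC2)c(C)o1` gives > 1390 10^-6 cm/s (a limit)

In a physicochemical assay for permeability, using PAMPA (a lower number here means that the compound crosses the layer more slowly, a higher number that the compound crosses the layer faster), compound 1 gives 455 10^-6 cm/s. Compound 2 stands at the limit of > 1390 10^-6 cm/s in this assay, at which 1 of the 2 values shown sits; this is a limit and not a number.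

Compound 3 `Cc1ccccc1-c1nc(CN2CCC(C(=O)NCCCN3CCC(C)CC3)CC2)c(C)o1` alters compound 2 in one place: a group of 7 heavy atoms (6 carbon, 1 nitrogen; one six-membered non-aromatic ring with 1 hetero atom) in place of a group of 10 heavy atoms (9 carbon, 1 nitrogen; one six-membered non-aromatic ring with 1 hetero atom), on a saturated chain carbon, three bonds along the chain from an amide-type nitrogen. The entering group is 4-methylpiperidin-1-yl, on a saturated chain carbon, three bonds along the chain from an amide-type nitrogen.

Going by the values given here, compound 1 and compound 2 differ in more than one place, so no measured step speaks directly to this change. Among the compounds with values here, a moderate fall in this assay is expected, with compound 1 at 455 10^-6 cm/s as the only exact number to lean on. The expected size is an at least 1.8-fold lower number from compound 2 to compound 3 (0.26 log units; that floor lies within the scatter). For compound 3 the estimate is 750 10^-6 cm/s, with an expected range from 300 10^-6 cm/s to 1400 10^-6 cm/s.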

Compound 3, apparent permeability: 425 10^-6 cm/s
Beside the measured number, compound 3's estimate is 1.8-fold (0.25 log units) above it; low and high end bracket the measured number.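

In this assay, going by these compounds alone, putting 4-methylpiperidin-1-yl in place of the group of 10 heavy atoms, on a saturated chain carbon, three bonds along the chain from an amide-type nitrogen, gives the first readable step at this position: an at least 3.2-fold lower number from compound 2 to compound 3 (0.51 log units; beyond the scatter). The reading for compound 2 is a limit and not a number: the limit of > 1390 10^-6 cm/s in this assay, at which 1 of the 3 values shown sits. Both groups are six-membered non-aromatic rings with 1 hetero atom, 0 hydrogen-bond donors, 1 hydrogen-bond acceptor and no net charge, so a change that leaves all of these the same and alters only the carbon count can still move the reading beyond the usual scatter.

Compound 1 differs from compound 3 in more than one place, so the number of carbons on this ring cannot be separated from where they sit. Going by these compounds, how an unsubstituted piperidine, a morpholine or a longer chain would read at this position remains open.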